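This account rests on a few compounds, and the source may have more. Where it says the series, first, only, none or still open, it means among the compounds named here.

Measured so far:
- compound 1, `CCOC(CC(=O)O)c1ccc(OCC2COc3ccc(Cl)cc3O2)cc1`: 46%
- compound 2, `CC#C[C@@H](CC(=O)O)c1ccc(OC[C@H]2COc3c(Cl)cccc3O2)cc1`: 81%
- compound 3, `CC#C[C@@H](CC(=O)O)c1ccc(OC[C@H]2COc3ccc(F)cc3O2)cc1`: 86%

All three were tested in a functional assay on HEK293 cells for agonist activity at Free fatty acid receptor 1 (Homo sapiens), read by fluorescence and calcium flux, with a stated time of 10 min; on this read-out higher numbers stand for larger maximal responses and lower numbers for smaller maximal responses. Compound 3 gives the highest of the three numbers, but its lead is uneven. Compound 2 sits within the usual scatter of compound 3, so the two cannot be told apart on this read-out. Compound 1 stands well apart: compound 1 gives 46%, while compound 3 gives 86%, a gap that lies beyond the scatter.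

The next compound, compound 4, `CC#C[C@@H](CC(=O)O)c1ccc(OC[C@H]2COc3ccc(OC)cc3O2)cc1`, is not yet measured. It differs from compound 3 in a single place: methoxy in place of fluoro on an aromatic carbon. Going by the values given here, no two measured compounds differ by one change alone, so no directly comparable step has been seen. The change is small. The expectation is therefore that the response of compound 4 stays close to that of compound 3, with a step of a number 6 percentage points lower from compound 3 to compound 4 (within the scatter) that is not expected to go beyond the scatter in either direction. On that basis compound 4 is estimated to reach 80%, within a range from 62% to 96%.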

Compound 4, largest response reached (Emax), in percent of the reference or control that the assay uses: 91%
For compound 4 the middle estimate is 11 percentage points below the measured one, and the stated range covers the measured number.
By their numbers in this assay, from the lowest: compound 1; then compounds 2, 3 and 4 (each within the scatter of the next).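

In this assay, going by these compounds alone, the swap of fluoro for methoxy on this aromatic carbon, which lies para to one fused ring and meta to the other, gives a first step in which a single change can be read on its own (a number 5 percentage points higher from compound 3 to compound 4 (within the scatter)). Compound 3 and compound 4 cannot be told apart on this read-out, so at this position a group of two heavy atoms with a hydrogen-bond acceptor serves as well as a single fluorine with none, at least for the largest response reached. No measurement shown here bears on why the response holds across this change.

With only fluoro and methoxy seen at this carbon in an otherwise shared structure, this single pair cannot show how large or how different a group the position accepts, for example a longer chain such as butoxy, an amine or a carboxylic acid. It also leaves open whether the same swap would behave alike on the core of compound 1, which carries an ethoxy group on its side chain where compound 3 and compound 4 carry a propynyl group.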